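The source may report more compounds than this note shows. Statements on the series, on what has been measured and on what is new or still open speak of the compounds shown alone.

Compound 1, `CC(C)[C@H](NC(=O)COc1cccc2ccccc12)C(=O)N[C@@H](CC(=O)O)C(=O)COc1cc(C(F)(F)F)n(C)n1`: 46000 nM
Compound 2, `CC(C)[C@H](NC(=O)COc1cccc2ccccc12)C(=O)N[C@@H](CC(=O)O)C(=O)CSc1nc(-c2ccccc2)cs1`: > 200000 nM

Both compounds were tested in a functional assay on Jurkat cells (Homo sapiens) for inhibition; a lower number here means a stronger inhibitor, a higher number a weaker inhibitor. For compound 2 the reported > 200000 nM is a limit of the assay rather than a number, so compound 2 stands at the limit of > 200000 nM in this assay, at which 1 of the 2 values shown sits.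

Compound 3, `CC(C)[C@H](NC(=O)COc1cccc2ccccc12)C(=O)N[C@@H](CC(=O)O)C(=O)CSc1nnnn1-c1ccccc1`, has not yet been measured in this assay. It differs from compound 2 in one place: 1-phenyl-1H-tetrazol-5-yl in place of 4-phenyl-1,3-thiazol-2-yl on a sulfur. For the measured compounds named here, the only measured step, an at least 4.3-fold higher number from compound 1 to compound 2 (0.63 log units; beyond the scatter), changed a different part of the molecule, so no measured step bears directly on the present change. Because compound 2 sits at the limit of > 200000 nM in this assay, at which 1 of the 2 values shown sits, its own position is not fixed, and the expectation for compound 3 must be wide.

The estimate for compound 3 is 150000 nM, expected to fall between 40000 nM and 500000 nM. The step this estimate implies is expected to be an at least 1.3-fold lower number from compound 2 to compound 3 (0.12 log units; that floor lies within the scatter).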

Compound 3, half-maximal inhibitory concentration: 153000 nM
Estimate against measurement, compound 3: 1.0-fold (0.01 log units) below, and the stated range covers the measured number.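

In this assay, the sulfur-linked side chain now has a true number rather than only a limit, and its size can be compared with the oxygen-linked side chain of compound 1. That comparison shows a real loss of inhibition when (1-phenyl-1H-tetrazol-5-yl)sulfanyl takes the place of (1-methyl-5-(trifluoromethyl)-1H-pyrazol-3-yl)oxy (a 3.3-fold higher number from compound 1 to compound 3 (0.52 log units; beyond the scatter)). The swap of the two rings on the sulfur gives only a floor that lies within the scatter (an at least 1.3-fold lower number from compound 2 to compound 3 (0.11 log units; that floor lies within the scatter)), so it cannot be sized, and compound 2 remains a limit of the assay rather than a number: the limit of > 200000 nM in this assay, at which 1 of the 3 values shown sits.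

The compounds shown leave open whether the sulfur link or the ring itself accounts for the loss, since both differ at once between compound 1 and compound 3. A 1-phenyl-1H-tetrazol-5-yl joined through oxygen instead of sulfur would separate the two.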